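Replacing the aminocyclitol with an open chain on a dialkylated aminoglycoside core

This account rests on a few compounds, and the source may have more. Where it says the series, first, only, none or still open, it means among the compounds named here.

Measured so far:
compound 1, `CCCCCCCCCO[C@@H]1[C@@H](N)[C@@H](O[C@H]2[C@H](O)[C@@H](O)[C@H](N)C[C@@H]2N)O[C@H](CN)[C@H]1OCCCCCCCCC`: 82.7%
compound 2, `C=CCO[C@H]1O[C@H](CN)[C@@H](OCc2ccc3ccccc3c2)[C@H](OCc2ccc3ccccc3c2)[C@H]1N`: 86.9%
compound 3, `CCCCCCCCCO[C@@H]1[C@@H](N)[C@@H](O[C@H]2[C@H](O)[C@@H](OCCCCCCCCC)[C@H](N)C[C@@H]2N)O[C@H](CN)[C@H]1O`: 78.4%

These values come from a toxicity assay on the whole organism (J774 cells) for cytotoxicity, with Mus musculus as the target, read by MTT assay, with a stated time of 24 h, tested at 10 uM; a lower number here means a stronger effect, a higher number a weaker effect of the compound at the concentration tested. Compound 1 gives a number that sits within the usual scatter of both compound 2 and compound 3, so the three compounds cannot be told apart in this assay.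

Compound 4, `CCCCCCCCCO[C@@H]1[C@@H](N)[C@@H](OCC(O)CNCCCN)O[C@H](CN)[C@H]1OCCCCCCCCC`, has not yet been measured. It differs from compound 1 in one place: 3-((3-aminopropyl)amino)-2-hydroxypropyl in place of 4,6-diamino-2,3-dihydroxycyclohexyl on an oxygen on a saturated carbon. Within the data shown here, no pair of measured compounds shows a step of this kind, so nothing here says how this assay responds to such a change.

Since all three measured numbers lie close together, the step from compound 1 to compound 4 is expected to be small, a number 6.7 percentage points lower from compound 1 to compound 4 (within the scatter), perhaps a little downward but not clearly beyond the scatter. For compound 4 the estimate is 76%, with a range from 55% to 92%.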

Compound 4, a percentage reported as activity, at one concentration (the size of the read-out at that concentration, not a potency): 101%
Compound 4: middle estimate off by 25 percentage points, on the low side; measured number outside the range, above it.
By their numbers in this assay, from the lowest: compounds 3, 1 and 2 (each within the scatter of the next); then compound 4.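

Unlike the earlier compounds, which could not be told apart, this pair shows that the read-out does respond to the group on this oxygen. In this assay, 3-((3-aminopropyl)amino)-2-hydroxypropyl in place of 4,6-diamino-2,3-dihydroxycyclohexyl gives a number 18.3 percentage points higher from compound 1 to compound 4 (beyond the scatter), a modest move towards a weaker effect at the concentration tested. Nothing available explains this shift.

One step cannot show whether losing the ring or gaining this particular chain matters more. As far as these compounds go, how a shorter open chain, such as a simple aminoethyl group, behaves on the same oxygen remains open.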